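The source may report more compounds than this note shows. Statements on the series, on what has been measured and on what is new or still open speak of the compounds shown alone.

Measured compounds in this series:
compound 1 `COC(=O)c1cccc(-c2cnc(C(=O)CCCCCCc3ccccc3)o2)c1`, 12 nM
compound 2 `O=C(CCCCCCc1ccccc1)c1ncc(-c2ccc([N+](=O)[O-])cc2)o1`, 50 nM
compound 3 `COC(=O)c1ccc(-c2cnc(C(=O)CCCCCCc3ccccc3)o2)nc1`, 3.5 nM

In an assay (Rattus norvegicus) for inhibition of Fatty-acid amide hydrolase 1 (Homo sapiens) (a lower number here means a stronger inhibitor, a higher number a weaker inhibitor), compound 2 stands at the highest number of the three; compound 1 lies at a lower number, and compound 3 lower still, both gaps beyond the scatter. The three measured compounds differ only in the group carried on the shared core, so that position clearly moves the number.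

Compound 4 `CNC(=O)c1cnc(C(=O)CCCCCCc2ccccc2)o1` differs from compound 2 by methylcarbamoyl in place of 4-nitrophenyl on an aromatic carbon. For the measured compounds named here, no step of this kind has been measured in the set, so the expectation rests on the general sensitivity of this position. A rise beyond the scatter is expected, with a 4.0-fold higher number from compound 2 to compound 4 (0.60 log units; beyond the scatter). Compound 4 is estimated at 200 nM, in the range 40 nM to 1000 nM.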

Compound 4, inhibition constant: 7 nM
Beside the measured number, compound 4's estimate is 29-fold (1.46 log units) above it, and the stated range ends above it.
By their numbers in this assay, from the lowest: compounds 3, 4 and 1 (each within the scatter of the next, the first and the last beyond it); then compound 2.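

In this assay, methylcarbamoyl in place of 4-nitrophenyl, on the aromatic carbon next to the ring oxygen, gives a 7.1-fold lower number from compound 2 to compound 4 (0.85 log units; beyond the scatter) and so moves the number down. The aromatic ring carried by compounds 1, 2 and 3 at this place is therefore not required for a low number, since compound 4 reaches 7 nM with a group that has no ring. Nothing available accounts for this step.

As far as these compounds go, whether the amide hydrogen of methylcarbamoyl matters remains open. So does how a carboxylic acid, a dimethylamide or a longer N-alkyl amide would read at this place.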